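The compounds below may be only part of what the source reports. "The series", "measured", "known", "first", "only" and "open" are said of these compounds alone.

The measured compounds:

Compound 1 `O=S(=O)(NCC1CCN(CCCc2c[nH]c3ccc(-n4cnnc4)cc23)CC1)c1ccccc1`: 60 nM
Compound 2 `C[C@@H](NCC1CCN(CCCc2c[nH]c3ccc(-n4cnnc4)cc23)CC1)c1ccccc1`: 14 nM
Compound 3 `c1ccc(CNCC2CCN(CCCc3c[nH]c4ccc(-n5cnnc5)cc34)CC2)cc1`: 28 nM

In an assay on CHO cells for displacement of a labelled ligand from 5-hydroxytryptamine receptor 1B (Homo sapiens) (on this read-out higher numbers stand for weaker inhibition and lower numbers for stronger inhibition), compound 3 gives the second highest of the three numbers. Its closest neighbour is compound 2: the step of a 2.0-fold higher number from compound 2 to compound 3 (0.30 log units; within the scatter) stays within the scatter, so the two cannot be ordered. Compound 1 lies further away, with a 2.1-fold lower number from compound 1 to compound 3 (0.33 log units; beyond the scatter) beyond the scatter, as is a 4.3-fold lower number from compound 1 to compound 2 (0.63 log units; beyond the scatter).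

Compound 4 `CC(=O)Nc1ccc([C@H](C)NCC2CCN(CCCc3c[nH]c4ccc(-n5cnnc5)cc34)CC2)cc1` differs from compound 3 in one place: 1-(4-acetamidophenyl)ethyl in place of benzyl on an amine nitrogen. Two parts of this change can be judged. The return of the methyl on the chain carbon is the reverse of the step from compound 2 to compound 3, which stayed within the scatter in this assay. Going by the values given here, the acetamido group on the aromatic ring has no counterpart among the measured compounds, so nothing in the data says how it will act. The expectation for compound 4 therefore rests on compound 2 and compound 3, whose values in this assay are within the scatter of each other, and the step of a 1.8-fold lower number from compound 3 to compound 4 (0.24 log units; within the scatter) is expected to be small, with the acetamido group as the open question. Compound 4 is estimated at 16 nM in this assay, with a range from 5 nM to 50 nM.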

Compound 4, half-maximal inhibitory concentration: 9.3 nM
Estimate against measurement, compound 4: 1.7-fold (0.24 log units) above, and the stated range covers the measured number.
By their numbers in this assay, from the lowest: compounds 4, 2 and 3 (each within the scatter of the next, the first and the last beyond it); then compound 1.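

Enlarging the group on the amine nitrogen does not cost binding in this assay: with the acetamido group on the aromatic ring of the 1-phenylethyl group, the step of a 1.5-fold lower number from compound 2 to compound 4 (0.18 log units; within the scatter) stays within the scatter, so compound 4 and compound 2 cannot be ordered. The two changes together do count against benzyl, for the step of a 3.0-fold lower number from compound 3 to compound 4 (0.48 log units; beyond the scatter) lies beyond the scatter, while the methyl alone gave only a 2.0-fold higher number from compound 2 to compound 3 (0.30 log units; within the scatter) and that step stayed within it. Compared with phenylsulfonyl, the step of a 6.5-fold lower number from compound 1 to compound 4 (0.81 log units; beyond the scatter) is the widest in the set and lies beyond the scatter, so this position tolerates 12 heavy atoms in the entering group, including a hydrogen-bond donor and acceptor, as long as the nitrogen stays an amine rather than a sulfonamide. No outside information bears on why these numbers fall as they do.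

The compounds shown leave open how the step from benzyl divides between the methyl and the acetamido group. They also leave open whether a methoxy group or a carboxylic acid in place of the acetamido group, or the opposite configuration at the chain carbon, would hold the number at this level.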